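Extending the amide arm from compound 2 to compound 4

The source may hold more compounds than are shown below. What is called first, only, known or untested is meant among the compounds shown, and "the series" means these compounds.

Measured compounds:
compound 1 `CCCCNC(=O)C1CCN(c2nc(N)c3cc(OC)c(OC)cc3n2)CC1` gives 0.67 nM
compound 2 `COc1cc2nc(N3CCC(C(=O)NCC4CC4)CC3)nc(N)c2cc1OC` gives 0.9 nM
compound 3 `COc1cc2nc(N3CCC(C(=O)Nc4ccccc4)CC3)nc(N)c2cc1OC` gives 0.47 nM

All three were tested in an assay on isolated protein for displacement of a labelled ligand from Adrenergic receptor alpha-1 (Rattus norvegicus); on this read-out higher numbers stand for weaker inhibition and lower numbers for stronger inhibition. Among them compound 2 carries the highest number, yet both of its neighbours sit inside the usual scatter: the step of a 1.3-fold higher number from compound 1 to compound 2 (0.13 log units; within the scatter) and the step of a 1.9-fold lower number from compound 2 to compound 3 (0.28 log units; within the scatter) are each small. The step of a 1.4-fold lower number from compound 1 to compound 3 (0.15 log units; within the scatter) is likewise within the scatter, so the three amide variants on the shared core cannot be ordered by this assay.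

Compound 4 `CCCCNC(=O)CCC1CCN(c2nc(N)c3cc(OC)c(OC)cc3n2)CC1` has not yet been measured. The change from compound 2 is 2-(butylcarbamoyl)ethyl in place of (cyclopropylmethyl)carbamoyl on a saturated ring carbon. Two aspects of this step find some echo in the measured pairs: the swap of cyclopropyl for propyl on the chain carbon, covered by a 1.3-fold higher number from compound 1 to compound 2 (0.13 log units; within the scatter), and the wider variation of the amide substituent covered by a 1.9-fold lower number from compound 2 to compound 3 (0.28 log units; within the scatter) and a 1.4-fold lower number from compound 1 to compound 3 (0.15 log units; within the scatter), none of which moved beyond the scatter. The insertion of the ethyl spacer between the ring carbon and the carbonyl is not covered by any measured pair, so that part of the change carries real uncertainty.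

On this basis compound 4 is expected to land close to compound 2, with a step of a 1.1-fold lower number from compound 2 to compound 4 (0.05 log units; within the scatter) not clearly beyond the scatter. The estimate for compound 4 is 0.8 nM, in the range 0.25 nM to 3 nM.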

Compound 4, inhibition constant: 0.47 nM
For compound 4 the middle estimate is 1.7-fold (0.23 log units) above the measured one, within the range that was stated.
By their numbers in this assay, from the lowest: compounds 3, 4, 1 and 2 (each within the scatter of the next).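

For the compounds shown here, the one new pair that differs only by the added ethyl unit has 2-(butylcarbamoyl)ethyl in place of butylcarbamoyl on a saturated ring carbon, and in this assay it reads a 1.4-fold lower number from compound 1 to compound 4 (0.15 log units; within the scatter), so on this core the carbonyl need not stand directly on that ring carbon for the value to stay within the scatter of compound 1. The two wider swaps agree: a 1.9-fold lower number from compound 2 to compound 4 (0.28 log units; within the scatter) and no change at the digits printed from compound 3 to compound 4 (within the scatter), so the open chain of 2-(butylcarbamoyl)ethyl is accepted at this position as readily as the (cyclopropylmethyl)carbamoyl and phenylcarbamoyl groups, and the four compounds still cannot be ordered by this read-out. Nothing among the data shown offers an explanation for so flat a response to this change.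

On these data alone, how far this tolerance reaches remains open: a longer chain ahead of the amide, a reversed amide, or a chain ending in a carboxylic acid or a free amine on the same ring carbon could still produce a step beyond the scatter. As far as these compounds go, it is also open whether a phenyl or cyclopropylmethyl amide on the extended ethyl arm would stay within the scatter of compound 4.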